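The source may hold more compounds than are shown below. What is called first, only, known or untested is meant among the compounds shown, and "the series" means these compounds.

Compound 2, `Cc1noc(C)c1-c1ccc2c(c1)C(c1ccccc1)N(Cc1nc(-c3ccc(F)cc3)cs1)C(=O)N2C`, is the stronger-looking of the two compounds measured in a functional assay on HCT-116 cells (Homo sapiens) for inhibition, read by MTT assay, with a stated time of 48 h, tested at 2 uM (a higher number here means more inhibition at the concentration tested (going by the name of the read-out), a lower number less inhibition), where compound 2 gives 33.3%. Its nearest neighbour is compound 1, `Cc1nc(-c2ccccc2)sc1CN1C(=O)N(C)c2ccc(-c3c(C)noc3C)cc2C1c1ccccc1`, which in this assay gives 28.3%; the step of a number 5 percentage points higher from compound 1 to compound 2 (within the scatter) stays within the scatter, so the two values cannot be ordered with confidence. Compound 3, `Cc1noc(C)c1-c1ccc2c(c1)C(c1ccccc1)N(Cc1nnc(-c3ccc(F)cc3)o1)C(=O)N2C`, has not been measured. It differs from compound 2 at the same place that separates compound 1 from compound 2: 5-(4-fluorophenyl)-1,3,4-oxadiazol-2-yl in place of 4-(4-fluorophenyl)-1,3-thiazol-2-yl on a saturated chain carbon bound to an amide-type nitrogen in a ring. Going by the values given here, the only measured step, from compound 1 to compound 2, exchanged one five-membered heteroaromatic group for another at this position and did not move the read-out beyond the scatter. Among the compounds with values here, no measured step shows the effect of this particular exchange, so the expectation rests on that single, small step. Compound 3 is therefore expected to sit close to compound 2, with an estimated step of a number 3.3 percentage points lower from compound 2 to compound 3 (within the scatter). The estimate for compound 3 is 30%, within a range from 15% to 45%.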

Compound 3, a percentage reported as inhibition, at one concentration (the size of the read-out at that concentration, not a potency): 36.6%
The estimate for compound 3 lay 6.6 percentage points below the measured number; low and high end bracket the measured number.
By their numbers in this assay, from the lowest: compounds 1, 2 and 3 (each within the scatter of the next).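

With the 4-fluorophenyl group kept, exchanging only the five-membered ring gives a number 3.3 percentage points higher from compound 2 to compound 3 (within the scatter), so a ring with three hetero atoms, oxygen among them and no sulfur, reads the same as the thiazole in this assay. The wider exchange gives a number 8.3 percentage points higher from compound 1 to compound 3 (within the scatter), which means that all three groups on this saturated chain carbon fall within the scatter of one another and cannot be ordered. No measurement is available to explain this lack of separation.

On these data alone, all three compounds carry a five-membered aromatic ring joined to a six-membered aromatic ring of carbon only, so it remains open whether this position can move the read-out at all. A carboxylic acid or an amine on the chain carbon in place of these ring groups would test that, as would a chlorine in place of the fluorine.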